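This account rests on a few compounds, and the source may have more. Where it says the series, first, only, none or still open, it means among the compounds named here.

The series shares the core of compound 1 `COc1cccc(CN2CC=C(CCC(=O)NO)C2=O)c1`, which in a functional assay on NUGC-3 cells (Homo sapiens) for antiproliferative activity (on this read-out lower numbers stand for stronger inhibition of growth and higher numbers for weaker inhibition of growth), gives 1750 nM. Compound 2 `O=C(CCC1=CCN(Cc2ccccc2)C1=O)NO` carries an unsubstituted benzyl group, and for compound 2 in this assay the outcome is "not determined" (no result reported), so it stands with no single number. Compound 3 `COc1ccccc1CN1CC=C(CCC(=O)NO)C1=O` differs from compound 2 by methoxy in place of hydrogen on an aromatic carbon. Within the data shown here, with no measured step on record for this change, the expectation rests on compound 1, whose value 1750 nM suggests a step in this assay of no more than the usual scatter in either direction. Compound 3 is therefore estimated at 1800 nM, expected within 600 nM to 5500 nM.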

Compound 3, concentration for 50% growth inhibition: > 10000 nM
Compound 3: no number, only a limit; the forecaster's own chance of this, stated with the estimate: 10%; middle value at least 5.5-fold (0.74 log units) away from the limit.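

No step can be read between compound 2 and compound 3: compound 2 has no reported result, and compound 3 has only a limit. Going by these compounds, the size and direction of any effect of methoxy in place of hydrogen stay open.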